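From Bromo to Dimethylamino: What to Expect for Compound 4

This account rests on a few compounds, and the source may have more. Where it says the series, first, only, none or still open, it means among the compounds named here.

Of the compounds shown here, three built on one shared core have been tested in a functional assay on A549 cells (Homo sapiens) for antiproliferative activity, read by sulforhodamine B assay, with a stated time of 48 h; on this read-out higher numbers stand for weaker inhibition and lower numbers for stronger inhibition. Compound 1, `COC(=O)c1cc(NC2=NC(=O)/C(=C/c3ccc(C)cc3)S2)ccc1O`, gives 2200 nM. Compound 3, `COC(=O)c1cc(NC2=NC(=O)/C(=C/c3ccc(Br)cc3)S2)ccc1O`, gives 8300 nM. Compound 2, `COC(=O)c1cc(NC2=NC(=O)/C(=C/c3ccccc3O)S2)ccc1O`, reaches only a limit of the method, recorded as > 10000 nM. Of the two real numbers, compound 3 stands highest, and its nearest neighbour is compound 1: the step of a 3.8-fold higher number from compound 1 to compound 3 (0.58 log units; beyond the scatter) is modest but beyond the scatter. The step of an at least 4.5-fold higher number from compound 1 to compound 2 (0.65 log units; beyond the scatter) is at least modest, while the step of an at least 1.2-fold lower number from compound 2 to compound 3 (0.08 log units; that floor lies within the scatter) has a floor that lies within the scatter.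

Compound 4, `COC(=O)c1cc(NC2=NC(=O)/C(=C/c3ccc(N(C)C)cc3)S2)ccc1O`, differs from compound 3 in one place: dimethylamino in place of bromo on an aromatic carbon. For the measured compounds named here, no measured pair shows exactly this exchange. The closest guide is the swap of methyl for bromo at the same aromatic carbon, the step of a 3.8-fold higher number from compound 1 to compound 3 (0.58 log units; beyond the scatter), which shows that the identity of the group at that carbon can shift the number modestly. Methyl there, in compound 1, gave 2200 nM, so a dimethylamino group may well pull the number back toward that level, though its own effect on this core is untested. Compound 4 is therefore expected to show the step of a 2.8-fold lower number from compound 3 to compound 4 (0.44 log units; beyond the scatter) in this assay. The estimate for compound 4 is 3000 nM, with a range from 900 nM to 10000 nM.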

Compound 4, half-maximal inhibitory concentration: 2400 nM
Compound 4: middle estimate off by 1.3-fold (0.10 log units), on the high side; measured number inside the range.
By their numbers in this assay, from the lowest: compounds 1 and 4 (each within the scatter of the next); then compound 3. At a limit, above all of these: compound 2.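

At this aromatic carbon, swapping bromo for dimethylamino recovers what the earlier swap of methyl for bromo had lost in this assay: the result is a 3.5-fold lower number from compound 3 to compound 4 (0.54 log units; beyond the scatter), while dimethylamino and methyl cannot be told apart, with a 1.1-fold higher number from compound 1 to compound 4 (0.04 log units; within the scatter). Among these three groups, then, bromo alone stands apart, and two groups with different atoms and different heavy-atom counts give matching numbers on the shared core. The change from 2-hydroxyphenyl to 4-(dimethylamino)phenyl gives an at least 4.1-fold lower number from compound 2 to compound 4 (0.61 log units; beyond the scatter), which is only a floor for the true size of that step, and the value of compound 2 is a limit rather than a number: the limit of > 10000 nM in this assay, at which 1 of the 4 values shown sits.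

From the compounds shown here alone, it remains open whether a simple amine, a methoxy group or a carboxylic acid at this same carbon would stay level with compound 1 and compound 4 or move the way compound 3 does. The compounds shown also leave open whether a hydroxy group at this carbon would behave as it does in the 2-hydroxyphenyl group of compound 2.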